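The source may report more compounds than this note shows. Statements on the series, on what has been measured and on what is new or still open speak of the compounds shown alone.

The account follows the three measured compounds and then one not yet measured. Compound 1 `Clc1ccc(-c2cc(-c3ccoc3)cc(-c3ccco3)n2)s1` gives 22700 nM in a functional assay on HeLa cells (Homo sapiens) for cytotoxicity, read by ELISA, with a stated time of 4 days; on this read-out lower numbers stand for stronger inhibition and higher numbers for weaker inhibition. Compound 2 `Cc1ccccc1-c1cc(-c2ccoc2)cc(-c2ccc(Cl)s2)n1` gives 19000 nM in this assay, and compound 3 `Clc1cccc(-c2cc(-c3ccoc3)cc(-c3ccc(Cl)s3)n2)c1` gives 23700 nM there. The steps among them are small: a 1.2-fold lower number from compound 1 to compound 2 (0.08 log units; within the scatter), a 1.0-fold higher number from compound 1 to compound 3 (0.02 log units; within the scatter) and a 1.2-fold higher number from compound 2 to compound 3 (0.10 log units; within the scatter), so compound 1 sits among the other two with no separation that the measurement can resolve.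

Compound 4 `Clc1ccc(-c2cc(-c3ccoc3)cc(-c3cccnc3)n2)s1` differs from compound 1 in one place: pyridin-3-yl in place of furan-2-yl on an aromatic carbon. Within the data shown here, the steps that bear on this change are those from compound 1 to compound 2 and from compound 1 to compound 3, in which the same furan-2-yl group was replaced by 2-methylphenyl and by 3-chlorophenyl; both stayed within the scatter. On that basis no step beyond the scatter is expected in this assay for compound 4, in either direction, and the estimated step is a 1.0-fold lower number from compound 1 to compound 4 (0.01 log units; within the scatter). Compound 4 is therefore expected to give about 22000 nM in this assay, within a range from 8000 nM to 60000 nM.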

Compound 4, half-maximal inhibitory concentration: 20000 nM
Beside the measured number, compound 4's estimate is 1.1-fold (0.04 log units) above it, within the range that was stated.
By their numbers in this assay, from the lowest: compounds 2, 4, 1 and 3 (each within the scatter of the next).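

In this assay, among these compounds, pyridin-3-yl brings a ring nitrogen into the group on this carbon next to the ring nitrogen of the shared core, and a 1.1-fold lower number from compound 1 to compound 4 (0.05 log units; within the scatter) shows that this change, like the two before it, gives no step the measurement can resolve. The same holds against the two groups without a hetero atom in their ring, with a 1.2-fold lower number from compound 3 to compound 4 (0.07 log units; within the scatter) and with a 1.1-fold higher number from compound 2 to compound 4 (0.02 log units; within the scatter) as well, so five- and six-membered aromatic rings with or without a hetero atom are not told apart at this position. Nothing available explains why this position shows so little response.

As far as these compounds go, all four groups here are aromatic rings, so it remains open whether an amine or a carboxylic acid at this position would give a step beyond the scatter. From the compounds shown here alone, it also remains open whether changes to the furan-3-yl group would do so.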